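A few compounds are considered here, and "the series" means these few. Any claim that something is new, unique, unknown or untested is made for them only; others in the source may bear on it.

Compound 1 `COc1ccc(C(=O)/C=C/c2ccccc2)cc1[N+](=O)[O-]` carries a nitro group, and compound 2 `COc1ccc(C(=O)/C=C/c2ccccc2)cc1N` is built from it by amino in place of nitro on an aromatic carbon. In a functional assay on B16 cells (Mus musculus) for cytotoxicity, read by MTT assay, with a stated time of 3 days (on this read-out lower numbers stand for stronger inhibition and higher numbers for weaker inhibition), compound 1 gives > 100000 nM, which is a limit of the assay rather than a number. In this assay compound 2 gives > 100000 nM, again only a limit. Because both values sit at the limit of > 100000 nM in this assay, at which 3 of the 3 values shown sit, the step that the two limits leave unreadable from compound 1 to compound 2 shows nothing about what the amino group does here: it could be large in either direction or nothing at all.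

Compound 3 `COc1ccc(/C=C/C(=O)c2ccc(OC)c([N+](=O)[O-])c2)cc1OC` keeps the nitro group but rests on a different core; the difference between the two cores is not broken down here. In this assay compound 3 gives > 100000 nM, once more a limit and not a number.

Compound 4 `COc1ccc(C(=O)/C=C/c2ccc(OC)c(OC)c2)cc1N` has not yet been tested in this assay. It differs from compound 3 by amino in place of nitro on an aromatic carbon, the same change that turns compound 1 into compound 2, and no other pair among the compounds shown carries this change. For the measured compounds named here, since the one measured instance of this change is a step that the two limits leave unreadable from compound 1 to compound 2, there is no readable step to lean on, and the expectation for compound 4 rests only on all three measured values sitting at the limit. The expected step that the limit leaves unreadable from compound 3 to compound 4 is therefore taken to be small, with a wide range of uncertainty. On that basis compound 4 is estimated at 150000 nM in this assay, somewhere between 20000 nM and 1000000 nM, and most likely it will also be reported as a limit rather than a number.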

Compound 4, half-maximal inhibitory concentration: 18000 nM
Compound 4: the middle estimate sits 8.3-fold (0.92 log units) above what was measured, outside the stated range (below it).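

In this assay, putting amino in place of nitro on the core of compound 3 gives an at least 5.5-fold lower number from compound 3 to compound 4 (0.74 log units; beyond the scatter). The value of compound 3 is a limit and not a number, so this size is only a floor, and the real step could be larger, but its direction is clear and it lies beyond the scatter. This shows that the change can lower the number on one core, but not that it carries over from one core to another, because the same change on the core of compound 1 joins two values that both sit at the limit and so cannot be read: the limit of > 100000 nM in this assay, at which 3 of the 4 values shown sit.

For the compounds shown here, with only one readable step, no size can be compared between the two cores, and it stays open whether the core of compound 1 would respond at all if its values could be brought within the range of the assay. From the compounds shown here alone, it also stays open whether amino itself matters or whether the loss of nitro is enough, which a plain hydrogen, a hydroxyl or an acetamide at the same place on either core could begin to separate.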